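Phenyl to benzyl on the ether oxygen in two benzothiophene-free cores

The compounds below may be only part of what the source reports. "The series", "measured", "known", "first", "only" and "open" are said of these compounds alone.

Measured so far:
compound 1, `COc1ccc2sc(C(=O)Nc3nn[nH]n3)c(Oc3ccccc3)c2c1`: 10100 nM
compound 2, `COc1ccc2sc(C(=O)Nc3nn[nH]n3)c(OCc3ccccc3)c2c1`: 23400 nM
compound 3, `CC(C)Oc1c(C(=O)Nc2nn[nH]n2)sc2ccc(Oc3ccccc3)cc12`: > 100000 nM

In a functional assay for inhibition, with Homo sapiens as the target (on this read-out higher numbers stand for weaker inhibition and lower numbers for stronger inhibition), compound 1 gives 10100 nM. Compound 2 carries the change benzyl in place of phenyl on an oxygen on an aromatic ring on the core of compound 1, and in this assay compound 2 gives 23400 nM. The step of a 2.3-fold higher number from compound 1 to compound 2 (0.36 log units; beyond the scatter) is the only measured instance of this change among the compounds shown.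

Compound 3 differs from compound 1 in more than one place, and the difference between the two cores is not broken down here. For compound 3 the read-out is only a limit, > 100000 nM, and not a number; the limit of > 100000 nM in this assay, at which 1 of the 3 values shown sits, is the mark at which it sits.

Compound 4, `CC(C)Oc1c(C(=O)Nc2nn[nH]n2)sc2ccc(OCc3ccccc3)cc12`, is compound 3 after the change (benzyl in place of phenyl on an oxygen on an aromatic ring). The place of this change is the same, word for word, as the place of the change from compound 1 to compound 2, so the two are the same change. On the core of compound 1 that change made the number larger, and compound 3 already sits at the limit, so compound 4 is expected to remain there or beyond, with the step that the limit leaves unreadable from compound 3 to compound 4 meant as an estimate resting on a 2.3-fold higher number from compound 1 to compound 2 (0.36 log units; beyond the scatter). For compound 4 the estimated value is 180000 nM, expected to lie between 70000 nM and 600000 nM, most likely reported only as a limit.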

Compound 4, half-maximal inhibitory concentration: > 100000 nM
Compound 4 was reported as a limit (the forecaster's own chance of this, stated with the estimate: 85%); the middle value is on the limit's open side.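

In this assay compound 4 gives > 100000 nM as a limit and not a number. Compound 3 is likewise reported only as a limit, so no step can be read between compound 3 and compound 4: the limit of > 100000 nM in this assay, at which 2 of the 4 values shown sit. The compounds shown leave open how far benzyl in place of phenyl on this oxygen shifts the read-out on the core of compound 3, or whether it shifts it at all.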